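Swapping a Ring-Bearing Side Chain for a Plain One

The compounds below may be only part of what the source reports. "The series", "measured", "known", "first", "only" and "open" are said of these compounds alone.

Of the compounds shown here, three have been measured in an assay for binding affinity to Corticotropin releasing factor receptor (Rattus norvegicus); a higher number here means a weaker inhibitor, a lower number a stronger inhibitor. Compound 1 `CCCC(C)n1c(CC)nc2c(-c3ccc(OC)nc3C(F)(F)F)ccnc21` gives 0.6 nM, and compound 2 `CCc1nc2c(-c3ccc(OC)nc3C(F)(F)F)ccnc2n1C(CC)C1CC1` gives 0.7 nM. Compound 3 `CCc1nc2c(-c3ccc(Cl)nc3C)ccnc2n1C(CC)C1CC1` gives 3.3 nM, the highest of the three numbers; both other compounds sit beyond the usual scatter from it, so compound 3 is the weakest binder among the measured set.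

Compound 1 and compound 2 share one core and differ in a single spot, on an aromatic nitrogen: 1-methylbutyl in place of 1-cyclopropylpropyl on an aromatic nitrogen. The measured step is a 1.2-fold lower number from compound 2 to compound 1 (0.07 log units; within the scatter). Compound 4 `CCCC(C)n1c(CC)nc2c(-c3ccc(Cl)nc3C)ccnc21`, not yet measured, is related to compound 3 by the same change: 1-methylbutyl in place of 1-cyclopropylpropyl on an aromatic nitrogen. The place is described in the same words for both pairs. How the core of compound 3 differs from the core of compound 2 is not broken down here.

Because a 1.2-fold lower number from compound 2 to compound 1 (0.07 log units; within the scatter), the same change on compound 3 is expected to move the number little, and the estimated step is a 1.2-fold lower number from compound 3 to compound 4 (0.07 log units; within the scatter). For compound 4 the expected value in this assay is 2.8 nM, with a likely range from 1.4 nM to 6 nM.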

Compound 4, inhibition constant: 6.6 nM
Compound 4: the middle estimate sits 2.4-fold (0.37 log units) below what was measured; measured number above the stated range.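

The new pair gives a 2.0-fold higher number from compound 3 to compound 4 (0.30 log units; within the scatter) in this assay, so replacing 1-cyclopropylpropyl with 1-methylbutyl on an aromatic nitrogen makes no change beyond the scatter on either core. Set side by side, the two steps cannot be told apart: the same change on two cores in this assay, a 1.2-fold lower number (0.07 log units; within the scatter) from compound 2 to compound 1 and a 2.0-fold higher number (0.30 log units; within the scatter) from compound 3 to compound 4, 2.3-fold (0.37 log units) apart, within the scatter of two such steps. This means the swap carries across these two cores without a detectable difference, but two pairs cannot show that it would do so on other cores, and a real difference smaller than the scatter would go unseen.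

The compounds shown leave open how a different group on that nitrogen would fare, such as a longer chain like 1-ethylpentyl, or a side chain bearing a cyclobutyl ring. They also leave open how much the methoxy and trifluoromethyl groups of compound 2, or the chloro and methyl groups of compound 3, each contribute, as no compound shown changes one of these groups alone.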